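This account rests on a few compounds, and the source may have more. Where it says the series, first, only, none or still open, it means among the compounds named here.

Working notes on the thiosemicarbazone series in a functional assay on SGC-7901 cells (Homo sapiens) for antiproliferative activity, read by sulforhodamine B assay, with a stated time of 72 h; a lower number here means a stronger inhibitor, a higher number a weaker inhibitor.

Three measured members share the core. Compound 1, `CC(C)c1cccc(C(C)C)c1NC(=S)N/N=C/c1ccc2ccccc2n1`, gives 23500 nM in this assay. Compound 2, `S=C(N/N=C/c1ccc2ccccc2n1)Nc1cccc(Br)c1`, gives 78600 nM in this assay, the higher of the two numbers that are real values, and the gap to compound 1 lies beyond the usual scatter. Compound 3, `NC(=S)N/N=C/c1cnc2ccccc2n1`, reaches only the limit of this assay, > 100000 nM, which is a limit rather than a number; this is the situation described in the limit of > 100000 nM in this assay, at which 1 of the 3 values shown sits.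

The next compound is compound 4, `COc1ccccc1NC(=S)N/N=C/c1ccc2ccccc2n1`. Relative to compound 2 the change is 2-methoxyphenyl in place of 3-bromophenyl on an amide-type nitrogen.

Going by the values given here, no measured pair in the set differs in just this one place, so there is no directly comparable step to lean on. The two real values, from compound 1 and compound 2, both sit in the weak range, and compound 3 gives a limit; nothing here separates an aryl substituent's effect from the rest. The step from compound 2 to compound 4 is therefore expected to be small, in either direction, and within the scatter, as a 1.1-fold lower number from compound 2 to compound 4 (0.05 log units; within the scatter). For compound 4 in this assay the estimated value is 70000 nM, with a range from 25000 nM to 100000 nM, the expectation resting on compound 2 at 78600 nM.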

Compound 4, half-maximal inhibitory concentration: > 100000 nM
Compound 4: only a limit was reported; the forecaster's own chance of this, stated with the estimate: 35%; middle value at least 1.4-fold (0.15 log units) away from the limit.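

Going by these compounds alone, this is the first step that can be read at this position. In this assay, going by these compounds, 2-methoxyphenyl in place of 3-bromophenyl on the amide-type nitrogen gives an at least 1.2-fold higher number from compound 2 to compound 4 (0.10 log units; that floor lies within the scatter), so the change brings no gain, and the true size of the step stays unknown. Compound 4 gives > 100000 nM, which is a limit and not a number, and a second member of the series now stands there: the limit of > 100000 nM in this assay, at which 2 of the 4 values shown sit.

Whether the step follows from the bromine leaving or from the methoxy entering stays open, since no pair of compounds shown parts the two. Also open, on these data alone, is how the same nitrogen would read with a phenyl ring carrying an amine or a carboxylic acid, and whether any such group would bring the number clear of the limit.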